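A few compounds are considered here, and "the series" means these few. Any claim that something is new, unique, unknown or untested is made for them only; others in the source may bear on it.

Compound 1 `CCc1cc(C(C)=O)c(O)cc1OCCCCCC(C)(C)C#N`: 53%
Compound 2 `CCc1cc(C(C)=O)c(O)cc1OCCCC(C)(C)C(=O)O`: 43%

Of the compounds shown here, two have been measured in an assay on isolated protein for binding affinity to leukotriene B4 receptor 1 (Homo sapiens), tested at 1 uM; on this read-out lower numbers stand for less inhibition and higher numbers for more inhibition at the one concentration tested (going by the name of the read-out). Compound 1 gives 53%, the highest of the two numbers, and the nearest to it is compound 2, with a number 10 percentage points lower from compound 1 to compound 2 (within the scatter). On these numbers compound 1 cannot be called stronger than compound 2.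

Compound 3 `CCc1cc(C(C)=O)c(O)cc1OCCCCCCC(C)(C)c1nnn[nH]1` has not been measured. Compared with compound 1 the change is 2-(1H-tetrazol-5-yl)-2-methylpropyl in place of 1-cyano-1-methylethyl on a saturated chain carbon, five bonds along the chain from an oxygen on an aromatic ring. Going by the values given here, only the step from compound 1 to compound 2 bears on this, and that one, a number 10 percentage points lower from compound 1 to compound 2 (within the scatter), replaced the nitrile end of the chain with an acid end and stayed within the scatter. The change to compound 3 again alters the end of the chain, and no step beyond the scatter is therefore expected: a number 5 percentage points lower from compound 1 to compound 3 (within the scatter). Compound 3 is estimated at 48%, with a range from 25% to 72%.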

Compound 3, a percentage reported as inhibition, at one concentration (the size of the read-out at that concentration, not a potency): 67%
Estimate against measurement, compound 3: 19 percentage points below; measured number inside the range.
By their numbers in this assay, from the lowest: compounds 2 and 1 (each within the scatter of the next); then compound 3.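

In this assay the end of the chain can move the number beyond the scatter, which the earlier step to the acid end did not show: the change to 2-(1H-tetrazol-5-yl)-2-methylpropyl gives a number 14 percentage points higher from compound 1 to compound 3 (beyond the scatter) in this series. This place, five bonds along the chain from an oxygen on an aromatic ring, therefore accepts a five-membered aromatic ring with 4 hetero atoms in place of 1-cyano-1-methylethyl without any loss. Nothing available here accounts for the gain.

The change brings in both the ring and a longer chain, so the compounds shown do not separate the two. A carboxylic acid or a nitrile on the chain of compound 3, or the 1H-tetrazol-5-yl ring on the shorter chain of compound 2, would show which of them carries the step.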